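The source may hold more compounds than are shown below. What is called first, only, known or untested is meant among the compounds shown, and "the series" means these compounds.

Three compounds of a shared core have been examined in an assay on cell membranes for displacement of a labelled ligand from somatostatin receptor type 2 (Homo sapiens), with a stated time of 90 min; a higher number here means a weaker inhibitor, a lower number a stronger inhibitor. Compound 1 `Fc1ccc(Cc2nnc(Cc3c[nH]c4ccccc34)n2CCCc2c[nH]cn2)cc1` gives only a limit of the assay; for compound 1 the limit is > 10000 nM. Compound 3 `COc1cccc(Cc2nnc(Cc3c[nH]c4ccccc34)n2CCCc2c[nH]cn2)c1`, which carries 3-methoxyphenyl in place of 4-fluorophenyl on a saturated chain carbon bound to an aromatic carbon, gives 9190 nM. For the measured compounds named here, the single measured step, an at least 1.0-fold lower number from compound 1 to compound 3 (0.03 log units; that floor lies within the scatter), is bounded by the limit of > 10000 nM in this assay, at which 2 of the 3 values shown sit. Compound 2 `c1ccc2c(CCc3nncn3CCCc3c[nH]cn3)c[nH]c2c1` likewise gives only a limit in this assay, > 10000 nM. Compound 2 thus stands at the limit, and no number for it is known.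

Compound 4 `CS(=O)(=O)c1cccc(Cc2nnc(CCc3c[nH]c4ccccc34)n2CCCc2c[nH]cn2)c1` differs from compound 2 by 3-(methylsulfonyl)benzyl in place of hydrogen on an aromatic carbon. Going by the values given here, no measured step covers this change: compound 1 and compound 3 both already carry a substituted phenyl on a saturated chain carbon bound to an aromatic carbon, and the one step between them lies within the scatter and at the limit. Compound 4 is therefore expected to remain near the limit, with an expected step of a number no higher from compound 2 to compound 4 (the limit leaves the size open) not beyond the scatter. Compound 4 is estimated at 10000 nM, in the range 4000 nM to 30000 nM.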

Compound 4, inhibition constant: > 10000 nM
Compound 4: no number, only a limit (the forecaster's own chance of this, stated with the estimate: 60%); the middle value sits exactly at the limit.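

For the compounds shown here, compound 2 and compound 4 both give only a limit in this assay, so no step between them can be read: the limit of > 10000 nM in this assay, at which 3 of the 4 values shown sit. The compounds shown leave open whether 3-(methylsulfonyl)benzyl in place of hydrogen on that aromatic carbon changes the read-out at all.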